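Allyl to Isopropyl on the Aromatic Ether Oxygen

A few compounds are considered here, and "the series" means these few. Any claim that something is new, unique, unknown or untested is made for them only; others in the source may bear on it.

In a functional assay on NCI-H1650 cells (Homo sapiens) for cytotoxicity, read by MTT assay, with a stated time of 48 h (on this read-out lower numbers stand for stronger inhibition and higher numbers for weaker inhibition), compound 1 `CCOc1ccc2c(Cl)ccnc2c1` gives 3340 nM, and compound 2 `C=CCOc1ccc2c(Cl)ccnc2c1` gives 2280 nM. Compound 2 stands at the low end of these two numbers, but the step of a 1.5-fold lower number from compound 1 to compound 2 (0.17 log units; within the scatter) lies within the scatter, so the two are not told apart. For the measured compounds named here, that single step, a vinyl in place of a methyl on the chain bound to the aromatic ether oxygen, is the only measured change and bears on the present question only loosely. Compound 3 `CC(C)Oc1ccc2c(Cl)ccnc2c1` is not yet measured; it differs from compound 2 by isopropyl in place of allyl on an oxygen on an aromatic ring. Going by the values given here, the one measured change on that oxygen was small, and the new change again only reshapes the chain there, so no step beyond the scatter is expected in this assay in either direction. For compound 3 the estimate is 2800 nM, between 1200 nM and 6500 nM, an expected step of a 1.2-fold higher number from compound 2 to compound 3 (0.09 log units; within the scatter).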

Compound 3, half-maximal inhibitory concentration: 2310 nM
Compound 3: middle estimate off by 1.2-fold (0.08 log units), on the high side; low and high end bracket the measured number.
By their numbers in this assay, from the lowest: compounds 2, 3 and 1 (each within the scatter of the next).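

Compound 3 shows that, in this assay, branching at the chain carbon bound to the oxygen does not separate the compounds: the change gives a 1.0-fold higher number from compound 2 to compound 3 (0.01 log units; within the scatter) and leaves no step beyond the scatter, even though the double bond of allyl is gone. The added methyl on the saturated chain likewise gives a 1.4-fold lower number from compound 1 to compound 3 (0.16 log units; within the scatter) and also stays within the scatter, so ethyl, allyl and isopropyl on this oxygen cannot be told apart here. Nothing independent of these numbers bears on why they stay together.

The compounds shown leave open whether a group of another kind on this oxygen, such as an amine, a carboxylic acid or a longer chain, would give a step beyond the scatter. They also leave open whether the same holds for changes elsewhere on the shared core.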